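The compounds below may be only part of what the source reports. "The series", "measured", "known", "first", "only" and "open" are said of these compounds alone.

Values in a physicochemical assay for lipophilicity, at pH 7.4; on this read-out higher numbers stand for higher lipophilicity and lower numbers for lower lipophilicity:
- compound 1 `Cc1ccc(N(CC(C)C)S(=O)(=O)c2ccc3c(c2)C(=O)CC(C2CCOCC2)O3)c(C)c1`: 4.28
- compound 2 `CC(C)CN(c1cc2ccccc2s1)S(=O)(=O)c1ccc2c(c1)C(=O)CC(C1CCOCC1)O2`: 4.01
- compound 3 `CCc1ccc(N(CC(C)C)S(=O)(=O)c2ccc3c(c2)C(=O)CC(C2CCOCC2)O3)cc1`: 4.21

Compound 3 stands level with the other two, with the steps of a number 0.07 log units lower from compound 1 to compound 3 (within the scatter) and a number 0.20 log units higher from compound 2 to compound 3 (within the scatter). Compound 4 `CC(C)CN(c1ccc(N(C)C)cc1)S(=O)(=O)c1ccc2c(c1)C(=O)CC(C1CCOCC1)O2` differs from it in one place: dimethylamino in place of ethyl on an aromatic carbon. The group is dimethylamino in place of ethyl on an aromatic carbon. The measured steps, including a number 0.27 log units lower from compound 1 to compound 2 (within the scatter), all exchange carbon-rich or sulfur-bearing aryl groups, so none of them tests this change directly. A moderate fall in this assay is expected, an estimated a number 0.41 log units lower from compound 3 to compound 4 (beyond the scatter). For compound 4 the estimated value is 3.8, within an expected range of 3.4 to 4.2.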

Compound 4, distribution coefficient: 3.6
The estimate for compound 4 lay 0.20 log units above the measured number; the range from low to high includes it.
By their numbers in this assay, from the lowest: compound 4; then compounds 2, 3 and 1 (each within the scatter of the next).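

In this assay, going by these compounds alone, the change from ethyl to dimethylamino on an aromatic carbon gives the first single-group steps beyond the scatter (a number 0.61 log units lower from compound 3 to compound 4 (beyond the scatter)), whereas the earlier aryl exchanges all stayed within it. The 4-(dimethylamino)phenyl group also stands apart from the other groups on the sulfonamide nitrogen (a number 0.41 log units lower from compound 2 to compound 4 (beyond the scatter); a number 0.68 log units lower from compound 1 to compound 4 (beyond the scatter)). No supporting measurement accounts for this fall.

The compounds shown leave open whether an unsubstituted amino group, a methoxy group or a morpholine ring at this position would give a step of similar size.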